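Sulfonamide nitrogen substituents on a thiourea series

The compounds below may be only part of what the source reports. "The series", "measured", "known", "first", "only" and "open" are said of these compounds alone.

Measured compounds:
compound 1, `NS(=O)(=O)c1ccc(N/C(S)=N\c2ccnc3cc(C(F)(F)F)ccc23)cc1`, 36600 nM
compound 2, `CC(=O)NS(=O)(=O)c1ccc(N/C(S)=N\c2ccnc3cc(C(F)(F)F)ccc23)cc1`, 37600 nM
compound 3, `O=S(=O)(Nc1ncccn1)c1ccc(N/C(S)=N\c2ccnc3cc(C(F)(F)F)ccc23)cc1`, 37800 nM

All three share one core and differ only in what sits on the sulfonamide nitrogen. In a functional assay on AS49-RAW cells (Homo sapiens) for antiproliferative activity, read by sulforhodamine B assay, with a stated time of 48 h (a higher number here means a weaker inhibitor, a lower number a stronger inhibitor), compound 3 gives 37800 nM, the highest of the three numbers, yet its gaps to compound 1 and compound 2 are both within the scatter, so no ordering among them can be claimed.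

Compound 4, `COc1cc(NS(=O)(=O)c2ccc(N/C(S)=N\c3ccnc4cc(C(F)(F)F)ccc34)cc2)nc(OC)n1`, is not yet measured. It differs from compound 3 by 2,6-dimethoxypyrimidin-4-yl in place of pyrimidin-2-yl on a sulfonamide nitrogen.

Within the data shown here, the steps that bear on this place are a 1.0-fold higher number from compound 1 to compound 2 (0.01 log units; within the scatter), a 1.0-fold higher number from compound 1 to compound 3 (0.01 log units; within the scatter) and a 1.0-fold higher number from compound 2 to compound 3 (0.00 log units; within the scatter). Each exchange at the sulfonamide nitrogen left this assay unchanged beyond the scatter, whether hydrogen, acetyl or pyrimidin-2-yl stood there. The new group is larger and carries two more acceptors, but nothing measured here speaks for a shift in either direction. The expectation is therefore a step of a 1.0-fold higher number from compound 3 to compound 4 (0.00 log units; within the scatter), within the scatter. Compound 4 is estimated at 38000 nM, with a range of 15000 nM to 95000 nM.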

Compound 4, half-maximal inhibitory concentration: 64500 nM
For compound 4 the middle estimate is 1.7-fold (0.23 log units) below the measured one, and the stated range covers the measured number.
By their numbers in this assay, from the lowest: compounds 1, 2, 3 and 4 (each within the scatter of the next).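

Extending the sulfonamide nitrogen from hydrogen, acetyl and pyrimidin-2-yl to the larger 2,6-dimethoxypyrimidin-4-yl still gives no step beyond the scatter in this assay (a 1.7-fold higher number from compound 3 to compound 4 (0.23 log units; within the scatter); a 1.7-fold higher number from compound 2 to compound 4 (0.23 log units; within the scatter); a 1.8-fold higher number from compound 1 to compound 4 (0.25 log units; within the scatter)). Across these four substituents, then, no group on this nitrogen separates from the others, and no ranking of the compounds can be claimed. The added methoxy-bearing ring thus extends the range of groups at this position without yet revealing any dependence of the number on the substituent.

As far as these compounds go, whether an aminoalkyl chain or a carboxylic acid on this nitrogen would give a step beyond the scatter remains open. So does whether changes to the trifluoromethyl group or the thiourea, constant across all four compounds, would do so. No supporting measurement is available to bear on these numbers.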